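Dichlorophenyl Replaces Fluorophenyl on the Sulfonyl Sulfur

The compounds below may be only part of what the source reports. "The series", "measured", "known", "first", "only" and "open" are said of these compounds alone.

Compound 1, `O=S(=O)(c1ccccc1)c1cn(C2CCCNC2)c2ncccc12`: compound 1 gives 4.9 nM in an assay on HeLa cells for displacement of a labelled ligand from 5-hydroxytryptamine receptor 6 (Homo sapiens); a lower number here means a stronger inhibitor, a higher number a weaker inhibitor.
Compound 2, `O=S(=O)(c1ccccc1F)c1cn(C2CCCNC2)c2ncccc12`: compound 2 gives 2 nM in this assay.

Compound 2 holds the lowest of the two numbers, and compound 1 stands nearest; the change of hydrogen to fluoro on an aromatic carbon gave a 2.5-fold lower number from compound 1 to compound 2 (0.39 log units; beyond the scatter). Compound 3, `O=S(=O)(c1cc(Cl)cc(Cl)c1)c1cn(C2CCCNC2)c2ncccc12`, differs from compound 2 by 3,5-dichlorophenyl in place of 2-fluorophenyl on a sulfonyl sulfur. Within the data shown here, only the step from compound 1 to compound 2 bears on this, and only loosely, since it altered the same ring; that step was modest. Compound 3 is therefore expected to show a 1.5-fold higher number from compound 2 to compound 3 (0.18 log units; within the scatter), a shift within the scatter. The estimate for compound 3 is 3 nM, with a range from 1 nM to 10 nM.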

Compound 3, inhibition constant: 6.1 nM
Beside the measured number, compound 3's estimate is 2.0-fold (0.31 log units) below it; measured number inside the range.
By their numbers in this assay, from the lowest: compound 2; then compounds 1 and 3 (each within the scatter of the next).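

On the sulfonyl sulfur, the 2-fluorophenyl of compound 2 remains the better group in this assay: 3,5-dichlorophenyl in its place gave (a 3.1-fold higher number from compound 2 to compound 3 (0.48 log units; beyond the scatter)). Set against the plain phenyl, the same group gave (a 1.2-fold higher number from compound 1 to compound 3 (0.10 log units; within the scatter)), so the two chlorines leave compound 3 level with compound 1 and do not carry over the gain seen with fluoro. Nothing given here explains this difference between the two substituted rings. Still open, going by these compounds, is how a methoxy group or an amine on this ring would read, and whether 3,5-difluorophenyl would fall with compound 2 or with compound 3.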